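The source may report more compounds than this note shows. Statements on the series, on what has been measured and on what is new or still open speak of the compounds shown alone.

Measured in an ADME assay on NIH3T3 cells (Mus musculus) for cytotoxicity; on this read-out lower numbers stand for higher toxicity in this test and higher numbers for lower toxicity in this test:
- compound 1 `CCOC(=O)CN(C)CC#Cc1cc2ncnc(Nc3ccc(OCc4cccc(F)c4)c(Cl)c3)c2s1`: 52 uM
- compound 2 `Fc1cccc(COc2ccc(Nc3ncnc4cc(C#CCN5CCCC5)sc34)cc2Cl)c1`: 6.4 uM
- compound 3 `Fc1cccc(COc2ccc(Nc3ncnc4cc(C#CC5CCCC5)sc34)cc2Cl)c1`: > 100 uM, a limit of the assay

Compound 3 has no number in this assay and stands at the limit: the limit of > 100 uM in this assay, at which 1 of the 3 values shown sits. Compound 4 `CC(C)(C)OC(=O)N1CCC[C@H]1C#Cc1cc2ncnc(Nc3ccc(OCc4cccc(F)c4)c(Cl)c3)c2s1` differs from it by one change, with 1-(tert-butoxycarbonyl)pyrrolidin-2-yl in place of cyclopentyl on a triple-bonded carbon. Among the measured compounds shown here, two measured steps bear on this change: an at least 15-fold higher number from compound 2 to compound 3 (1.19 log units; beyond the scatter), which is large, and an at least 1.9-fold higher number from compound 1 to compound 3 (0.28 log units; that floor lies within the scatter). The step of an 8.1-fold lower number from compound 1 to compound 2 (0.91 log units; beyond the scatter) is modest. Compound 2 alone gives a low number, and the entering group matches neither side chain, so only a small downward move is expected. The expected step is an at least 1.2-fold lower number from compound 3 to compound 4 (0.09 log units; that floor lies within the scatter). The estimate for compound 4 is 80 uM, with an expected range of 30 uM to 150 uM.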

Compound 4, half-maximal toxic concentration: > 100 uM
Compound 4: only a limit was reported (the forecaster's own chance of this, stated with the estimate: 50%); middle value at least 1.2-fold (0.09 log units) from the limit.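

In this assay compound 4 joins compound 3 at a limit of the assay, so the step between them cannot be read: the limit of > 100 uM in this assay, at which 2 of the 4 values shown sit. Compound 4 carries a pyrrolidine ring, as compound 2 does, yet the result is an at least 15-fold higher number from compound 2 to compound 4 (1.19 log units; beyond the scatter), so that ring alone does not bring the low number at this position. Against the open-chain amine the result is an at least 1.9-fold higher number from compound 1 to compound 4 (0.28 log units; that floor lies within the scatter).

On these data alone, it remains open whether the free pyrrolidin-2-yl group, with a secondary amine in place of the tert-butoxycarbonyl group, would give a low number. Any order among the side chains at the limit also remains open.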